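This account rests on a few compounds, and the source may have more. Where it says the series, first, only, none or still open, it means among the compounds named here.

Compound 1, `Nc1ccccc1NC(=O)c1ccc(CSC(=S)N2CCN(Cc3ccncc3)CC2)cc1`: 79.3%
Compound 2, `Nc1ccccc1NC(=O)c1ccc(CSC(=S)N2CCN(c3ccccc3F)CC2)cc1`: 86.4%

Of the compounds shown here, two sharing one core have been measured in a functional assay on MGC-803 cells (Homo sapiens) for antiproliferative activity, read by CCK-8 assay, with a stated time of 72 h, tested at 8 uM; a higher number here means a stronger effect of the compound at the concentration tested, a lower number a weaker effect. Compound 2 stands at the upper end of the pair, but a number 7.1 percentage points higher from compound 1 to compound 2 (within the scatter) does not separate it from compound 1, so the two read as alike. Among the measured compounds shown here, the only step in hand concerns the same place that is now varied: the group on the amine nitrogen in the ring, where 2-fluorophenyl replaced (pyridin-4-yl)methyl with no effect beyond the scatter.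

The next compound, compound 3, `Nc1ccccc1NC(=O)c1ccc(CSC(=S)N2CCN(Cc3ccccc3)CC2)cc1`, differs from compound 2 by benzyl in place of 2-fluorophenyl on an amine nitrogen in a ring. A benzyl group resembles the (pyridin-4-yl)methyl of compound 1 in being attached through a one-carbon link, and since the change from compound 1 to compound 2 at this place was within the scatter, no step beyond the scatter is expected here either; if anything, a drift back toward the value of compound 1 is expected. Compound 3 is therefore estimated at 82%, between 72% and 90%, corresponding to an expected a number 4.4 percentage points lower from compound 2 to compound 3 (within the scatter).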

Compound 3, a percentage reported as inhibition, at one concentration (the size of the read-out at that concentration, not a potency): 19.7%
The estimate for compound 3 lay 62.3 percentage points above the measured number, outside the stated range (below it).
By their numbers in this assay, from the lowest: compound 3; then compounds 1 and 2 (each within the scatter of the next).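

In this assay, the group on the amine nitrogen in the ring proves able to decide the read-out, a point the pair of compound 1 and compound 2 could not show: benzyl in place of 2-fluorophenyl gives a number 66.7 percentage points lower from compound 2 to compound 3 (beyond the scatter), although each group holds one six-membered aromatic ring of carbon only. The attachment through a chain carbon does not by itself go with the low number, since phenyl in place of pyridin-4-yl on the saturated chain carbon bound to that nitrogen gives a number 59.6 percentage points lower from compound 1 to compound 3 (beyond the scatter), so the ring on that carbon matters as well as the group's link to the nitrogen. Nothing at hand offers an explanation for either large step.

On these data alone, it remains open how 2-fluorobenzyl, phenyl or 2-phenylethyl on the same nitrogen would stand, and so whether the low number belongs to benzyl alone or extends to a wider set of groups. With a read-out at a single concentration, the potency differences among these compounds also remain open.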